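The source may report more compounds than this note shows. Statements on the series, on what has been measured and on what is new or still open speak of the compounds shown alone.

Compound 3 `CN(C)CCN(CCN(C)C)c1cccc(C(=O)N2CCc3ccc(OS(N)(=O)=O)cc3C2)c1` gives 0% in an assay on HEK293 cells for inhibition of Steryl-sulfatase (Homo sapiens), tested at 0.1 uM (a lower number here means a weaker effect, a higher number a stronger effect of the compound at the concentration tested), the lowest of the three numbers: compound 1 `CCN(Cc1ccccc1)c1cccc(C(=O)N2CCc3ccc(OS(N)(=O)=O)cc3C2)c1` gives 17.3% and compound 2 `CN(CCCN1CCCCC1)c1cccc(C(=O)N2CCc3ccc(OS(N)(=O)=O)cc3C2)c1` gives 24.1%. Compound 4 `CC(C)CCN(CCC(C)C)c1cccc(C(=O)N2CCc3ccc(OS(N)(=O)=O)cc3C2)c1` differs from compound 3 by diisopentylamino in place of bis(2-(dimethylamino)ethyl)amino on an aromatic carbon. Going by the values given here, the steps that bear on this change are those that arrived at compound 3: a number 17.3 percentage points lower from compound 1 to compound 3 (beyond the scatter) and a number 24.1 percentage points lower from compound 2 to compound 3 (beyond the scatter), each a modest fall beyond the scatter, while a number 6.8 percentage points higher from compound 1 to compound 2 (within the scatter) lies within it. Since both exchanges of the group on that aromatic carbon away from compound 3 sit higher, a rise of similar size is expected, a number 18 percentage points higher from compound 3 to compound 4 (beyond the scatter). Compound 4 is therefore estimated at 18%, with a range from 5% to 35%.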

Compound 4, a percentage reported as inhibition, at one concentration (the size of the read-out at that concentration, not a potency): 32.3%
For compound 4 the middle estimate is 14.3 percentage points below the measured one; the measured number falls inside the stated range.
By their numbers in this assay, from the lowest: compound 3; then compounds 1, 2 and 4 (each within the scatter of the next, the first and the last beyond it).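

In this assay the exchange, with 11 heavy atoms on both sides and 1 nitrogen entering against 3 leaving, gives a number 32.3 percentage points higher from compound 3 to compound 4 (beyond the scatter) and is the largest step yet seen on this aromatic carbon. Diisopentylamino also separates from benzyl(ethyl)amino, with a number 15 percentage points higher from compound 1 to compound 4 (beyond the scatter), whereas a number 8.2 percentage points higher from compound 2 to compound 4 (within the scatter) leaves it level with methyl(3-(piperidin-1-yl)propyl)amino. No measurement at hand explains these steps. Still open, on these data alone, is how shorter chains such as diethylamino, or chains ending in a hydroxyl or a carboxylic acid, would compare on this carbon.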